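The compounds below may be only part of what the source reports. "The series", "measured", "known", "first", "only" and "open" are said of these compounds alone.

Measured in an ADME assay (liver) for metabolic stability, with Liver microsome (Rattus norvegicus) as the target, using microsomes and NADPH, with a stated time of 30 min, tested at 1 uM; on this read-out higher numbers stand for fast clearance and lower numbers for slow clearance:
- compound 1 `COc1cc(C(O)(C(F)(F)F)C(F)(F)F)cnc1N1CCN(S(=O)(=O)c2ccc(N)nc2)CC1`: < 14 mL.min-1.g-1, a limit of the assay
- compound 2 `CCn1cc(-c2cc(C(O)(C(F)(F)F)C(F)(F)F)cnc2N2CCN(S(=O)(=O)c3ccc(N)nc3)CC2)cn1`: 194 mL.min-1.g-1
- compound 3 `Nc1ccc(S(=O)(=O)N2CCN(c3ncc(C(O)(C(F)(F)F)C(F)(F)F)cc3-c3ccoc3)CC2)cn1`: 57 mL.min-1.g-1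

Of the two true numbers in this assay, the lower belongs to compound 3, while compound 1 is known only through its limit. Compound 4 `Nc1ccc(S(=O)(=O)N2CCN(c3ncc(C(O)(C(F)(F)F)C(F)(F)F)cc3-c3cccnc3)CC2)cn1` carries pyridin-3-yl in place of furan-3-yl on an aromatic carbon.

Among the measured compounds shown here, no measured compound has this group, so the nearest guide is the exchange of one aromatic ring for another at the same carbon, a 3.4-fold lower number from compound 2 to compound 3 (0.53 log units; beyond the scatter), which is modest. The two steps away from methoxy are larger: an at least 13-fold higher number from compound 1 to compound 2 (1.14 log units; beyond the scatter) and an at least 4.0-fold higher number from compound 1 to compound 3 (0.60 log units; beyond the scatter). Both aromatic groups measured so far thus gave higher numbers than the methoxy of compound 1, and compound 4 is expected to follow them. A change beyond the scatter is not expected, and the direction remains uncertain. The expected step is a 1.3-fold lower number from compound 3 to compound 4 (0.10 log units; within the scatter). For compound 4 the estimated value is 45 mL.min-1.g-1, with an expected range from 16 mL.min-1.g-1 to 130 mL.min-1.g-1.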

Compound 4, intrinsic clearance in microsomes: 20 mL.min-1.g-1
Estimate against measurement, compound 4: 2.3-fold (0.35 log units) above; the measured number falls inside the stated range.
By their numbers in this assay, from the lowest: compound 4; then compound 3; then compound 2. At a limit, below all of these: compound 1.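

Replacing furan-3-yl with pyridin-3-yl at this aromatic carbon gave a 2.9-fold lower number from compound 3 to compound 4 (0.45 log units; beyond the scatter), and replacing 1-ethyl-1H-pyrazol-4-yl with it gave a 9.7-fold lower number from compound 2 to compound 4 (0.99 log units; beyond the scatter), so the three aromatic rings shown are separated from one another in this assay, with pyridin-3-yl lowest. Both earlier rings had stood clearly above methoxy, whereas for pyridin-3-yl the step reads an at least 1.4-fold higher number from compound 1 to compound 4 (0.15 log units; that floor lies within the scatter), so an aromatic ring at this carbon need not lie far above methoxy. That comparison rests on a limit of the assay for compound 1: the limit of < 14 mL.min-1.g-1 in this assay, at which 1 of the 4 values shown sits.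

No phenyl group stands at this carbon among these compounds, so they do not separate the ring nitrogen of pyridin-3-yl from the six-membered ring as such. As far as these compounds go, how pyridin-4-yl or an amine would read here stays open, as does the true number of compound 1.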